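The source may hold more compounds than are shown below. What is called first, only, known or untested is meant among the compounds shown, and "the series" means these compounds.

Compound 2 `CC(Sc1nc2c(cnn2C)c(=O)n1-c1ccccc1)c1ccccc1` is the shortest-lived of the two numbers given in an ADME assay on microsomes from liver (Mus musculus, strain CD-1) for metabolic stability, read by LC-MS, with a stated time of 60 min, tested at 20 uM; on this read-out higher numbers stand for a longer-lived compound and lower numbers for a shorter-lived compound: compound 2 gives 0.133 h, while compound 1 `CC(Sc1nc2c(cnn2C)c(=O)n1-c1ccccc1)c1ccccn1` gives 0.833 h. Compound 3 `CC(Sc1nc2nn(C3COC3)cc2c(=O)n1-c1ccccc1)c1ccccn1` reaches only a limit of this assay, > 1 h, and that limit is the limit of > 1 h in this assay, at which 1 of the 3 values shown sits. For the measured compounds named here, the one measured step that bears on the question is a 6.3-fold lower number from compound 1 to compound 2 (0.80 log units; beyond the scatter). Compound 4 `CC(Sc1nc2c(cnn2C)c(=O)n1-c1ccccc1)c1cccnc1` differs from compound 2 by pyridin-3-yl in place of phenyl on a saturated chain carbon bound to a saturated chain carbon and a sulfur. A return from phenyl to a pyridyl ring points back toward the number of compound 1, though the nitrogen now sits elsewhere in the ring, so an increase in this assay is expected from compound 2 to compound 4 of about a 3.8-fold higher number from compound 2 to compound 4 (0.58 log units; beyond the scatter). Compound 4 is therefore estimated at 0.5 h, within a range from 0.2 h to 1.2 h.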

Compound 4, half-life: 0.117 h
For compound 4 the middle estimate is 4.3-fold (0.63 log units) above the measured one; measured number below the stated range.
By their numbers in this assay, from the lowest: compounds 4 and 2 (each within the scatter of the next); then compound 1. At a limit, above all of these: compound 3.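

In this assay a ring nitrogen on this saturated chain carbon does not by itself go with the higher number of compound 1: pyridin-3-yl reads like phenyl (a 1.1-fold lower number from compound 2 to compound 4 (0.06 log units; within the scatter)), while the move between the two pyridyl rings is large (a 7.1-fold lower number from compound 1 to compound 4 (0.85 log units; beyond the scatter)). Among these compounds, then, where the nitrogen sits in the ring counts, not merely that the ring holds one. Nothing measured here explains this difference between pyridin-2-yl and pyridin-3-yl. Still open, going by these compounds, is whether a nitrile or an amine on the pyridin-2-yl ring would keep the number of compound 1 in this assay.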